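Aryl swap on the shared core: expectation for compound 3

This account rests on a few compounds, and the source may have more. Where it says the series, first, only, none or still open, it means among the compounds named here.

In an ADME assay on L6 cells (Rattus norvegicus) for cytotoxicity, read by resazurin assay, with a stated time of 72 h (on this read-out higher numbers stand for weaker inhibition and lower numbers for stronger inhibition), compound 1 (`OC(c1ccc(Cl)cc1)(c1cccnc1)c1ccccc1Cl`) gives 61300 nM and compound 2 (`OC(c1ccc(Cl)cc1)(c1cccnc1)c1cccc(F)c1`) gives 66000 nM as its value, so compound 2 stands level with compound 1 within the scatter. Compound 3 (`OC(c1ccc(Cl)cc1)(c1ccc(Br)cc1)c1cccnc1`) carries 4-bromophenyl in place of 3-fluorophenyl on a saturated chain carbon bound to two aromatic carbons and an oxygen on a saturated carbon. Among the compounds with values here, the one measured step at this place (a 1.1-fold higher number from compound 1 to compound 2 (0.03 log units; within the scatter)) lies within the scatter, so this assay is expected to show no step beyond it. The expected step is a 1.2-fold lower number from compound 2 to compound 3 (0.08 log units; within the scatter) and stays within the scatter. Compound 3 is estimated at 55000 nM (expected range 25000 nM to 105000 nM).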

Compound 3, half-maximal inhibitory concentration: 57000 nM
Estimate against measurement, compound 3: 1.0-fold (0.02 log units) below; the range from low to high includes it.
By their numbers in this assay, from the lowest: compounds 3, 1 and 2 (each within the scatter of the next).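

In this assay, 4-bromophenyl at this place on the saturated chain carbon reads level with both earlier aryl groups (a 1.2-fold lower number from compound 2 to compound 3 (0.06 log units; within the scatter)) and (a 1.1-fold lower number from compound 1 to compound 3 (0.03 log units; within the scatter)). The three halogen-bearing phenyl groups in compound 1, compound 2 and compound 3 therefore stand within the scatter of one another, so swapping the halogen-bearing phenyl group here has not yet moved this read-out. Nothing on hand offers an explanation for this flat result.

Still open, from the compounds shown here alone, is whether a group without a halogen at this place, such as an amine-bearing phenyl, a carboxylic acid or a longer chain, would give a step beyond the scatter.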